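Swapping an Anilino Phenyl for a Hexyl Chain

The source may hold more compounds than are shown below. What is called first, only, known or untested is meant among the compounds shown, and "the series" means these compounds.

Measured so far:
- Compound 1, `OC[C@H]1OC(n2cnc3c(Nc4ccccc4)nccc32)[C@H](O)[C@@H]1O`: 4%
- Compound 2, `CC1OC(n2cnc3c(N)nccc32)CC1O`: 3%
- Compound 3, `CN(C)c1[nH]ccc2ncnc1-2`: 8%

In a functional assay (Homo sapiens) for inhibition of Nucleic Acid, tested at 100 uM (on this read-out higher numbers stand for more inhibition at the one concentration tested (going by the name of the read-out) and lower numbers for less inhibition), all three compounds sit close together, and every gap among them lies within the usual scatter, so none of the numbers can be called higher or lower than another. Compound 1 stands second highest of the three numbers; compound 2 lies nearest to it and compound 3 furthest, yet both differences remain within the scatter.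

The new compound 4, `CCCCCCNc1nccc2c1ncn2C1O[C@H](CO)[C@@H](O)[C@H]1O`, differs from compound 1 in one place: hexyl in place of phenyl on a nitrogen on an aromatic ring. Among the compounds with values here, no comparable step exists among the measured compounds to lean on. Given that every value so far is small, no step beyond the scatter is expected; the change a number 1 percentage points higher from compound 1 to compound 4 (within the scatter) is expected to be slight. Compound 4 is estimated at 5%, with a likely range from -5% to 15%.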

Compound 4, a percentage reported as inhibition, at one concentration (the size of the read-out at that concentration, not a potency): 8%
Beside the measured number, compound 4's estimate is 3 percentage points below it, and the stated range covers the measured number.
By their numbers in this assay, from the lowest: compounds 2, 1, 3 and 4 (each within the scatter of the next).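

Putting hexyl in place of phenyl on this nitrogen gives a number 4 percentage points higher from compound 1 to compound 4 (within the scatter) in this assay and so leaves the read-out unchanged within the scatter. Within the data shown here, this is the first step that can be read, and it shows that here an open chain and an aromatic ring of the same carbon count cannot be told apart. Nothing available explains this result.

As far as these compounds go, whether a benzyl group, a shorter chain such as butyl or a chain ending in an amine on this nitrogen would stand clear of the scatter stays open. From the compounds shown here alone, it also stays open whether any change at this position can bring more than slight inhibition at the one concentration tested.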